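Compound 3 to compound 4: cyano in place of chloro

The compounds below may be only part of what the source reports. "The series", "measured", "known", "first", "only" and "open" are said of these compounds alone.

Measured in a functional assay on THP-1 cells (Homo sapiens) for cytotoxicity, read by MTT assay, with a stated time of 24 h; a lower number here means a stronger inhibitor, a higher number a weaker inhibitor
- compound 1 `COc1cc(/C=C2\CN(C)C/C(=C\c3ccc(Cl)cc3)C2=O)cc(OC)c1` at 5860 nM
- compound 2 `COc1cc(/C=C2\CN(C)C/C(=C\c3cccc([N+](=O)[O-])c3)C2=O)cc(OC)c1` at 1770 nM
- compound 3 `COc1cc(/C=C2\CN(C)C/C(=C\c3ccc(Cl)cc3)C2=O)cc(OC)c1OC` at 7200 nM

Compound 3 (at 7200 nM) lies within the scatter of compound 1 (at 5860 nM), while compound 2 (at 1770 nM) carries a lower number than either.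

Compound 4 `COc1cc(/C=C2\CN(C)C/C(=C\c3ccc(C#N)cc3)C2=O)cc(OC)c1OC` differs from compound 3 as follows: cyano in place of chloro on an aromatic carbon (cyano in place of chloro on an aromatic carbon, para to a large group, 4-chlorophenyl to 4-cyanophenyl).

Within the data shown here, two measured steps bear on this change. The methoxy addition gave a 1.2-fold higher number from compound 1 to compound 3 (0.09 log units; within the scatter), so a result obtained on compound 1 may reasonably carry over to compound 3. The only measured replacement of the 4-chlorophenyl group, by a nitrophenyl group, gave a 3.3-fold lower number from compound 1 to compound 2 (0.52 log units; beyond the scatter) as a modest step. Among the measured compounds shown here, no cyano compound has been measured, and that single step is an imperfect guide, so a similar direction but a somewhat smaller size is expected in this assay, with a return to the scatter not excluded. The expected change is a 2.1-fold lower number from compound 3 to compound 4 (0.31 log units; beyond the scatter) in this estimate. For compound 4 the estimated value is 3500 nM (expected range 1500 nM to 8000 nM).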

Compound 4, half-maximal inhibitory concentration: 820 nM
Compound 4: the middle estimate sits 4.3-fold (0.63 log units) above what was measured, and the stated range ends above it.
By their numbers in this assay, from the lowest: compound 4; then compound 2; then compounds 1 and 3 (each within the scatter of the next).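

Cyano in place of chloro gives an 8.8-fold lower number from compound 3 to compound 4 (0.94 log units; beyond the scatter) in this assay, and nothing else differs between the two structures, so the group on this aromatic carbon, para to a large group, can by itself move the number well beyond the scatter. The only earlier replacement, 3-nitrophenyl in place of 4-chlorophenyl, changed both the group and its place on the ring, whereas 4-chlorophenyl to 4-cyanophenyl keeps the place and changes the group alone, and it does so on the core that carries the added methoxy. No measurement shown accounts for the size of this step.

The compounds shown leave open whether cyano gives a comparable step on the core of compound 1, which lacks that methoxy, and whether the step depends on the place of the group, since 3-cyanophenyl does not appear among them. They also leave open how an amine, a carboxylic acid or a longer chain on this aromatic carbon would compare with cyano in this assay.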